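Hemolysis series: allyl on the thiourea nitrogen across two cores

A few compounds are considered here, and "the series" means these few. Any claim that something is new, unique, unknown or untested is made for them only; others in the source may bear on it.

Measured so far:
compound 1 `NC(=S)N/N=C\c1ccccc1OCc1ccc2no[n+]([O-])c2c1` gives 189 uM
compound 2 `C=CCNC(=S)N/N=C\c1ccccc1OCc1ccc2no[n+]([O-])c2c1` gives 139 uM
compound 3 `CC1(C)[N+]([O-])=c2ccc(COc3ccc(/C=N/NC(N)=S)cc3)cc2=[N+]1[O-]` gives "nd(insoluble)" (no result reported)

In an ADME assay on cells (Erythrocyte, Homo sapiens), read by spectrophotometry and hemolysis, with a stated time of 24 h (on this read-out lower numbers stand for stronger inhibition and higher numbers for weaker inhibition), compound 1 gives 189 uM and compound 2 gives 139 uM. Compound 2 carries allyl in place of hydrogen on an amide-type nitrogen, and the step of a 1.4-fold lower number from compound 1 to compound 2 (0.13 log units; within the scatter). Compound 3 rests on a different core; the difference between the two cores is not broken down here, and in this assay compound 3 returned no number. Compound 4 `C=CCNC(=S)N/N=C/c1ccc(OCc2ccc3c(c2)=[N+]([O-])C(C)(C)[N+]=3[O-])cc1` carries the same change on the core of compound 3, (allyl in place of hydrogen on an amide-type nitrogen), at the same place as before. Compound 4 is expected to land near the values of compound 1 and compound 2, because a 1.4-fold lower number from compound 1 to compound 2 (0.13 log units; within the scatter) lies within the scatter and gives no reason to expect a large shift. From the compounds shown here alone, no number for compound 3 exists, so the starting point is unknown and a result without a number remains possible. In this assay compound 4 is estimated at 150 uM, between 50 uM and 450 uM.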

Compound 4, concentration for 50% inhibition: > 100 uM
Compound 4 ended at the assay's limit (the forecaster's own chance of this, stated with the estimate: 45%); the middle value does not contradict the limit.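

For compound 4, > 100 uM is a limit of the assay and not a number. For the compounds shown here, with no single number for compound 3 either, no step from compound 3 to compound 4 can be read. Open remains whether allyl in place of hydrogen changes the read-out on the core of compound 3.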